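The source may hold more compounds than are shown below. What is called first, only, known or untested is meant among the compounds shown, and "the series" means these compounds.

Measured in a functional assay on KBVIN cells (Homo sapiens) for antiproliferative activity, read by sulforhodamine B assay, with a stated time of 3 days; a lower number here means that less compound is needed, a higher number that more compound is needed for the effect:
- Compound 1 `CCC1=C(O)c2c(oc(-c3ccc(F)cc3)cc2=O)C(CC)(CC)C1=O`: 1.85 uM
- Compound 2 `CCC1=C(O)c2c(oc(-c3ccc(OC)c(C)c3)cc2=O)C(CC)(CC)C1=O`: 0.1 uM
- Compound 3 `CCC1=C(O)c2c(oc(-c3ccc(O)c(C)c3C)cc2=O)C(CC)(CC)C1=O`: 2.75 uM

Compound 3 sits at the high end of these numbers, which means more compound is needed: a 1.5-fold higher number from compound 1 to compound 3 (0.17 log units; within the scatter), and a 28-fold higher number from compound 2 to compound 3 (1.44 log units; beyond the scatter). Compound 4 `CCC1=C(O)c2c(oc(-c3cc(C)c(O)c(C)c3)cc2=O)C(CC)(CC)C1=O` has the same atoms, joined differently: 4-hydroxy-3,5-dimethylphenyl in place of 4-hydroxy-2,3-dimethylphenyl on an aromatic carbon. For the measured compounds named here, no measured step moves a methyl alone. Still, a 19-fold lower number from compound 1 to compound 2 (1.27 log units; beyond the scatter) shows that changing this aromatic group can matter greatly. The new group keeps the hydroxy of compound 3, yet its name is closer to the 4-methoxy-3-methylphenyl of compound 2 at 0.1 uM. A moderate drop is therefore expected, a 2.8-fold lower number from compound 3 to compound 4 (0.44 log units; beyond the scatter). For compound 4 the estimate is 1 uM, with an expected range of 0.25 uM to 3.5 uM.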

Compound 4, concentration for half-maximal effect: 8.9 uM
The estimate for compound 4 lay 8.9-fold (0.95 log units) below the measured number; measured number above the stated range.
By their numbers in this assay, from the lowest: compound 2; then compounds 1 and 3 (each within the scatter of the next); then compound 4.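

In this assay, swapping 4-hydroxy-2,3-dimethylphenyl for 4-hydroxy-3,5-dimethylphenyl keeps the same atoms yet gives a 3.2-fold higher number from compound 3 to compound 4 (0.51 log units; beyond the scatter), so this position responds to the arrangement of the ring's groups and not only to which groups are present. The new group also gives a 4.8-fold higher number from compound 1 to compound 4 (0.68 log units; beyond the scatter) and an 89-fold higher number from compound 2 to compound 4 (1.95 log units; beyond the scatter), the largest step seen so far at this position. Nothing measured here explains these shifts.

The aromatic groups of compound 2 and compound 4 differ in both their methyl and oxygen groups, so those two effects remain unseparated. Going by these compounds, how an amine or a longer chain would behave on this ring remains open.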